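Series notes: the step to compound 3

The source may hold more compounds than are shown below. What is called first, only, known or untested is meant among the compounds shown, and "the series" means these compounds.

Measured so far in an ADME assay on MDCKII-LE cells (Canis lupus familiaris) for permeability (on this read-out lower numbers stand for lower permeability and higher numbers for higher permeability), as follows
- compound 1 `CNC(=O)c1cnc(Oc2cc(C(=O)Nc3cnc(C)cn3)cc3oc(C)cc23)cn1` (20.9 10^-6 cm/s)
- compound 2 `Cc1cc2c(Oc3cnc(C(=O)N4CC(C)C4)cn3)cc(C(=O)Nc3cnccn3)cc2o1` (14.9 10^-6 cm/s)

Compound 2 and compound 1 lie within the scatter of each other, so compound 2 has no separate standing on these numbers. Going by the values given here, two values show no trend, and no measured pair differs in one place only. Compound 3 `Cc1cc2c(Oc3cnc(C(=O)N4CC5(COC5)C4)cn3)cc(C(=O)Nc3cnccn3)cc2o1` differs from compound 2 on a carbonyl carbon, where 3-methylazetidin-1-yl leaves, with a group of 7 heavy atoms (5 carbon, 1 nitrogen, 1 oxygen; 2 four-membered non-aromatic rings with 1 hetero atom each) in place of a group of 5 heavy atoms (4 carbon, 1 nitrogen; one four-membered non-aromatic ring with 1 hetero atom), on a carbonyl carbon as the counted change. In this assay a step no larger than the scatter is expected, leaning slightly towards lower numbers, with compound 2 at 14.9 10^-6 cm/s as the only starting point. The estimated size is a 1.4-fold lower number from compound 2 to compound 3 (0.13 log units; within the scatter) on this expectation. For compound 3 the expected value is 11 10^-6 cm/s within an estimated range of 5.5 10^-6 cm/s to 20 10^-6 cm/s for now.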

Compound 3, apparent permeability in the MDCKII-LE assay: 19.9 10^-6 cm/s
Compound 3: the middle estimate sits 1.8-fold (0.26 log units) below what was measured; measured number inside the range.
By their numbers in the MDCKII-LE assay, from the lowest: compounds 2, 3 and 1 (each within the scatter of the next).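

On the carbonyl carbon, replacing 3-methylazetidin-1-yl with the group carrying 2 four-membered non-aromatic rings and 1 hydrogen-bond acceptor gives, in the MDCKII-LE assay, a 1.3-fold higher number from compound 2 to compound 3 (0.13 log units; within the scatter) and leaves the two compounds indistinguishable on this read-out (compound 2 at 14.9 10^-6 cm/s and compound 3 at 19.9 10^-6 cm/s). The same replacement gives, in a physicochemical assay for solubility, measured as kinetic solubility (a higher number here means a more soluble compound, a lower number a less soluble compound), a 1.1-fold lower number from compound 2 to compound 3 (0.06 log units; within the scatter) and the two compounds again cannot be told apart (compound 2 at 49000 nM and compound 3 at 43000 nM). This position therefore accepts a larger group with a second four-membered ring and a hydrogen-bond acceptor without a step beyond the scatter in either assay, though this rests on one pair only.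

Still open, going by these compounds, is how a piperazine, a carboxylic acid or a longer chain on this carbonyl carbon would read in these two assays. No measured information is at hand that accounts for either step.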